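Three inactive sulfonamides and a fourth awaiting its reading

The compounds below may be only part of what the source reports. "The series", "measured", "known", "first", "only" and "open" are said of these compounds alone.

Compound 1 `O=S(=O)(Nc1ccc(-c2nc3ccccc3o2)cc1)c1ccc(O)cc1` gives only a limit of the assay, > 63000 nM.
Compound 2 `O=S(=O)(Nc1ccc2oc(-c3ccccc3)nc2c1)c1ccccc1O` gives only a limit, > 63000 nM.
Compound 3 `O=S(=O)(Nc1ccc(-c2nc3ccccc3o2)cc1)c1ccc(C(F)(F)F)cc1` gives only a limit, > 63000 nM.

All three were tested in an assay on isolated protein for inhibition of malate dehydrogenase, mitochondrial (Sus scrofa), with stated times of 45 min and 30 min (a higher number here means a weaker inhibitor, a lower number a stronger inhibitor), and sit at the limit of > 63000 nM in this assay, at which 3 of the 3 values shown sit. The change from compound 1 to compound 3, (trifluoromethyl in place of hydroxy on an aromatic carbon), made a step that the two limits leave unreadable from compound 1 to compound 3. Compound 2 holds the same atoms as compound 1 joined differently; the difference between the two cores is not broken down here. Compound 4 `O=S(=O)(Nc1ccc2oc(-c3ccccc3)nc2c1)c1ccccc1C(F)(F)F` differs from compound 2 by trifluoromethyl in place of hydroxy on an aromatic carbon, the same kind of change, set ortho to a large group rather than para to a large group. In this assay the step from compound 2 to compound 4 is expected to be a step that the limit leaves unreadable from compound 2 to compound 4, resting on the unreadable step that the two limits leave unreadable from compound 1 to compound 3. Compound 4 is estimated at 100000 nM, most likely again a limit.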

Compound 4, half-maximal inhibitory concentration: > 63000 nM
Compound 4: no number, only a limit; the forecaster's own chance of this, stated with the estimate: 85%; the middle value is on the limit's open side.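

Compound 4 gives only a limit, > 63000 nM, so no step can be read between compound 2 and compound 4. The compounds shown leave open how strongly any of them inhibits in this assay, because all share one ceiling: the limit of > 63000 nM in this assay, at which 4 of the 4 values shown sit.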